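Moving the Pyridine Nitrogen in a Sulfamate Series

The compounds below may be only part of what the source reports. "The series", "measured", "known", "first", "only" and "open" are said of these compounds alone.

Compound 2 `CCN(Cc1ccccn1)c1cccc(C(=O)N2CCc3ccc(OS(N)(=O)=O)cc3C2)c1` gives 6.5% in an assay on HEK293 cells for inhibition of Steryl-sulfatase (Homo sapiens), tested at 0.1 uM (a lower number here means a weaker effect, a higher number a stronger effect of the compound at the concentration tested), the smallest of the three numbers recorded. Compound 3 `CN(C)CCN(Cc1ccccc1)c1ccc(C(=O)N2CCc3ccc(OS(N)(=O)=O)cc3C2)cc1`, with 13.9%, lies within the scatter of compound 2, so the two cannot be told apart, whereas compound 1 `CN(CCCN1CCCCC1)c1ccc(C(=O)N2CCc3ccc(OS(N)(=O)=O)cc3C2)cc1`, with 17.4%, sits beyond it. Compound 4 `CCN(Cc1cccnc1)c1cccc(C(=O)N2CCc3ccc(OS(N)(=O)=O)cc3C2)c1` is built from compound 2 by a single change: pyridin-3-yl in place of pyridin-2-yl on a saturated chain carbon bound to a nitrogen on an aromatic ring. Going by the values given here, no pair of measured compounds shows this change, so its effect cannot be read from the data. With nothing to lean on, compound 4 is expected to stay close to compound 2, with an expected step of a number 1.5 percentage points higher from compound 2 to compound 4 (within the scatter) that should not reach beyond the scatter. Compound 4 is therefore estimated at 8%, within a range from 0% to 18%.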

Compound 4, a percentage reported as inhibition, at one concentration (the size of the read-out at that concentration, not a potency): 14.3%
Compound 4: the middle estimate sits 6.3 percentage points below what was measured, and the stated range covers the measured number.
By their numbers in this assay, from the lowest: compounds 2, 3, 4 and 1 (each within the scatter of the next, the first and the last beyond it).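

Going by these compounds alone, the change of pyridin-2-yl to pyridin-3-yl on a saturated chain carbon bound to a nitrogen on an aromatic ring gives the first direct reading at this place, with a number 7.8 percentage points higher from compound 2 to compound 4 (within the scatter) in this assay. At this single concentration, therefore, the two pyridine arrangements cannot be told apart, and moving the ring nitrogen has no resolved effect. No supporting data bear on this step.

The compounds shown leave open how pyridin-4-yl would read at this place. They also leave open whether a propyl group in place of the ethyl on the same nitrogen would shift the number beyond the scatter.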